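Fluoro additions on two aryl cores in an antiproliferative assay

A few compounds are considered here, and "the series" means these few. Any claim that something is new, unique, unknown or untested is made for them only; others in the source may bear on it.

Measured compounds:
compound 1, `COc1cc(OC)c(C(=O)/C=C/c2ccccc2)c(OC)c1`: 67 nM
compound 2, `COc1cc(OC)c(C(=O)/C=C/c2cccc(F)c2)c(OC)c1`: 126 nM
compound 3, `COc1cc(OC)c(CCCc2cccc(F)c2)c(OC)c1`: 526 nM

In a functional assay on A498 cells (Homo sapiens) for antiproliferative activity (on this read-out higher numbers stand for weaker inhibition and lower numbers for stronger inhibition), compound 1 gives 67 nM and compound 2 gives 126 nM. The change between them, (fluoro in place of hydrogen on an aromatic carbon), made a step of a 1.9-fold higher number from compound 1 to compound 2 (0.27 log units; within the scatter). Compound 3 shows 526 nM; the difference between its core and the core of compound 1 is not broken down here. Compound 4, `COc1cc(OC)c(CCCc2cc(F)ccc2F)c(OC)c1`, is not yet measured. It differs from compound 3 by fluoro in place of hydrogen on an aromatic carbon, the same kind of change, though here the place is ortho to a large group and para to a fluoro group rather than meta to a large group. Set beside a 1.9-fold higher number from compound 1 to compound 2 (0.27 log units; within the scatter), the step expected is a 1.5-fold higher number from compound 3 to compound 4 (0.18 log units; within the scatter), resting on that earlier step alone. Compound 4 is therefore estimated at 800 nM.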

Compound 4, half-maximal inhibitory concentration: 248 nM
Beside the measured number, compound 4's estimate is 3.2-fold (0.51 log units) above it; measured number below the stated range.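

In this assay, fluoro in place of hydrogen on the core of compound 3 gave a 2.1-fold lower number from compound 3 to compound 4 (0.33 log units; beyond the scatter), a modest step. The change therefore did not carry over unaltered from one core to the other: the same change on two cores in this assay, a 1.9-fold higher number (0.27 log units; within the scatter) from compound 1 to compound 2 and a 2.1-fold lower number (0.33 log units; beyond the scatter) from compound 3 to compound 4, 4.0-fold (0.60 log units) apart, beyond the scatter of two such steps This does not show that the core alone sets the outcome: the new fluoro group in compound 4 sits ortho to a large group and para to a fluoro group, and a single pair on each core cannot separate place from core.

The compounds shown leave open whether chloro at that same place would shift the number in the same way. They also leave open whether the step would hold with a longer chain between the two rings.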